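Two Limits and a Cyclohexyl Amide

A few compounds are considered here, and "the series" means these few. Any claim that something is new, unique, unknown or untested is made for them only; others in the source may bear on it.

Compound 1, `CC1CC(C(=O)N2CCc3nc(C#Cc4ccccc4)sc3C2)C1`, was tested in an assay on HEK293 cells for negative allosteric modulation of metabotropic glutamate receptor 5 (Homo sapiens), read by FLIPR, with a stated time of 1 h; a higher number here means a weaker inhibitor, a lower number a stronger inhibitor. In this assay compound 1 gives > 10000 nM, which is a limit of the assay rather than a measured number. Compound 2, `COC1CC(C(=O)N2CCc3nc(C#Cc4ccccc4)sc3C2)C1`, carries a methoxy in place of a methyl on a saturated ring carbon. In this assay compound 2 gives > 10000 nM, again a limit and not a number. The step that the two limits leave unreadable from compound 1 to compound 2 is therefore unreadable, with both values sitting at the limit of > 10000 nM in this assay, at which 2 of the 2 values shown sit. Compound 2 thus stands only at a limit, with no measured number to place it.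

Compound 3, `O=C(C1CCCCC1)N1CCc2nc(C#Cc3ccccc3)sc2C1`, is the next change: cyclohexyl in place of 3-methoxycyclobutyl on a carbonyl carbon. Among the measured compounds shown here, the one measured step, from compound 1 to compound 2, has no readable size, so it gives no guide to the direction or size of a change in this assay. All that is known is that both measured compounds sit at the limit. The step of a number no higher from compound 2 to compound 3 (the limit leaves the size open) is expected to show no readable size, with both ends at the limit. Compound 3 is therefore estimated at 10000 nM, within a range from 3000 nM to 30000 nM, most likely reported once more only as a limit.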

Compound 3, half-maximal inhibitory concentration: > 10000 nM
Compound 3: only a limit was reported; the forecaster's own chance of this, stated with the estimate: 80%; the middle value lies on the limit itself.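

In this assay compound 3 gives > 10000 nM which is a limit of the assay and not a number. No step among compound 1, compound 2 and compound 3 can be read, since all three stop at the same point: the limit of > 10000 nM in this assay, at which 3 of the 3 values shown sit.

As far as these compounds go, how strong each of these three compounds really is, and whether the changes among them make any difference, stays open.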